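The source may hold more compounds than are shown below. What is called first, only, known or untested is meant among the compounds shown, and "the series" means these compounds.

Working notes on an isoquinoline-amide series tested in a functional assay on NUGC-3 cells (Homo sapiens) for inhibition, read by sulforhodamine B assay, with a stated time of 48 h; a higher number here means a weaker inhibitor of growth, a lower number a stronger inhibitor of growth.

Compound 1 `O=C(Nc1ccccc1Cl)c1nccc2ccccc12` carries chloro on an aromatic carbon, ortho to a large group. In this assay compound 1 is reported only as a limit, > 10000 nM. Compound 2 `O=C(Nc1cccc(Cl)c1)c1nccc2ccccc12` has the same atoms as compound 1 joined differently; the difference between the two cores is not broken down here. In this assay compound 2 likewise gives only a limit, > 10000 nM. Compound 3 `COc1ccccc1NC(=O)c1nccc2ccccc12` is obtained from compound 1 by the following change: methoxy in place of chloro on an aromatic carbon In this assay compound 3 also stops at a limit, > 10000 nM. The step that the two limits leave unreadable from compound 1 to compound 3 is therefore of unknown size. All three values share one feature: the limit of > 10000 nM in this assay, at which 3 of the 3 values shown sit.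

Compound 4 `COc1cccc(NC(=O)c2nccc3ccccc23)c1` has not been measured. It stands to compound 2 as follows: methoxy in place of chloro on an aromatic carbon The place is not the same as before: there the methoxy enters ortho to a large group, here meta to a large group, so this is the same kind of change rather than the same change.

For compound 4 in this assay a value near 20000 nM is expected, most likely again returned only as a limit, with a range of 8000 nM to 60000 nM. The expected step is a step that the limit leaves unreadable from compound 2 to compound 4, resting on the unreadable step that the two limits leave unreadable from compound 1 to compound 3 and on (the limit of > 10000 nM in this assay, at which 3 of the 3 values shown sit).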

Compound 4, concentration for 50% growth inhibition: > 10000 nM
Compound 4: a limit, no number (the forecaster's own chance of this, stated with the estimate: 85%); the middle value does not contradict the limit.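

In this assay compound 4 is reported only as a limit, > 10000 nM. No step from compound 2 to compound 4 can be read, because neither compound has a numerical value: the limit of > 10000 nM in this assay, at which 4 of the 4 values shown sit.

The compounds shown leave open whether methoxy in place of chloro changes growth inhibition at all, and how any of these compounds ranks against the others.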